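Fluoro to chloro on compound 2

The source may report more compounds than this note shows. Statements on the series, on what has been measured and on what is new or still open speak of the compounds shown alone.

In an ADME assay on Vero cells (Chlorocebus sabaeus) for cytotoxicity, read by resazurin assay, with a stated time of 72 h (on this read-out higher numbers stand for weaker inhibition and lower numbers for stronger inhibition), compound 1 `COc1ccc(C(=O)CCN2CCN(c3ccc([N+](=O)[O-])cc3)CC2)cc1` reads 587000 nM while compound 2 `O=C(CCN1CCN(c2ccc([N+](=O)[O-])cc2)CC1)c1ccc(F)c(F)c1` reads 122000 nM as the lower of only these two numbers. Compound 3 `O=C(CCN1CCN(c2ccc([N+](=O)[O-])cc2)CC1)c1ccc(F)c(Cl)c1` keeps the core of compound 2 but has chloro in place of fluoro on an aromatic carbon, ortho to a fluoro group and meta to a large group (chloro in place of fluoro on an aromatic carbon). This turns 3,4-difluorophenyl into 3-chloro-4-fluorophenyl. Going by the values given here, only one measured step bears on this change: a 4.8-fold lower number from compound 1 to compound 2 (0.68 log units; beyond the scatter) when 3,4-difluorophenyl took the place of 4-methoxyphenyl. That modest step, beyond the scatter, came from a larger structural change than the present one. In this assay a smaller step is therefore expected, probably within the scatter and perhaps slightly toward a lower number. The step expected is a 1.2-fold lower number from compound 2 to compound 3 (0.09 log units; within the scatter). The estimate for compound 3 is 100000 nM in a range from 40000 nM to 250000 nM.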

Compound 3, half-maximal inhibitory concentration: 116000 nM
For compound 3 the middle estimate is 1.2-fold (0.06 log units) below the measured one, within the range that was stated.
By their numbers in this assay, from the lowest: compounds 3 and 2 (each within the scatter of the next); then compound 1.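

In this assay, placing chloro instead of fluoro on this aromatic carbon, ortho to a fluoro group, gives a 1.1-fold lower number from compound 2 to compound 3 (0.02 log units; within the scatter), so the two halogens cannot be told apart here. The separation from the 4-methoxyphenyl compound also remains with the new halogen, at a 5.1-fold lower number from compound 1 to compound 3 (0.70 log units; beyond the scatter), which shows that this separation does not depend on having fluoro at this one position. No measurement is available to explain why fluoro and chloro read alike at this position.

The compounds shown leave open whether a group of another kind at this position, such as bromo, trifluoromethyl or an amine, would move the number beyond the scatter. Also open, from the compounds shown here alone, is whether the same swap would read alike if the fluoro group that stays were replaced by hydrogen.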